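The source may report more compounds than this note shows. Statements on the series, on what has been measured and on what is new or still open speak of the compounds shown alone.

Going by the values given here, compound 3 `O=C1COc2ccc(-c3[nH]c(-c4ccc(C(F)(F)F)cc4)nc3-c3ccccc3)cc2N1` gives 103% in a functional assay on A549 cells (Homo sapiens) for cytotoxicity, read by colorimetric assay and MTT assay, with a stated time of 3 days, tested at 1 uM (on this read-out lower numbers stand for a stronger effect and higher numbers for a weaker effect at the one concentration tested), the highest of the three numbers so far, though this standing rests on steps that are all within the scatter. Compound 1 `COc1ccc(-c2nc(-c3ccccc3)c(-c3ccc4c(c3)NC(=O)CO4)[nH]2)cc1` gives 101% in this assay. Compound 2 `O=C1COc2ccc(-c3[nH]c(-c4ccccc4)nc3-c3ccccc3)cc2N1` gives 95.6% in this assay. The steps between them are small: a number 5.4 percentage points lower from compound 1 to compound 2 (within the scatter), a number 2 percentage points higher from compound 1 to compound 3 (within the scatter), and a number 7.4 percentage points higher from compound 2 to compound 3 (within the scatter). Nothing in the set separates one substituent from another on this read-out at the single concentration.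

Compound 4 `O=C1COc2ccc(-c3[nH]c(-c4ccc(F)cc4)nc3-c3ccccc3)cc2N1` is not yet measured. The change from compound 3 is fluoro in place of trifluoromethyl on an aromatic carbon. The steps that touch the trifluoromethyl group, namely a number 2 percentage points higher from compound 1 to compound 3 (within the scatter) and a number 7.4 percentage points higher from compound 2 to compound 3 (within the scatter), both stayed within the scatter, so removing most of it in favour of fluoro is expected to give no step beyond the scatter in this assay; the expected step is a number 3 percentage points lower from compound 3 to compound 4 (within the scatter). Compound 4 is estimated at 100%, with a range from 88% to 112%.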

Compound 4, a percentage reported as activity, at one concentration (the size of the read-out at that concentration, not a potency): 97.1%
Estimate against measurement, compound 4: 2.9 percentage points above; the range from low to high includes it.
By their numbers in this assay, from the lowest: compounds 2, 4, 1 and 3 (each within the scatter of the next).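

In this assay the change from trifluoromethyl to fluoro gives (a number 5.9 percentage points lower from compound 3 to compound 4 (within the scatter)), the change from hydrogen to fluoro gives (a number 1.5 percentage points higher from compound 2 to compound 4 (within the scatter)) and the change from methoxy to fluoro gives (a number 3.9 percentage points lower from compound 1 to compound 4 (within the scatter)). Fluoro thus joins the other three groups on this aromatic carbon, para to a large group, with no step beyond the scatter, so none of the four groups is separated from another on this read-out at the one concentration tested. No supporting data bear on this result.

On these data alone, whether an amine, a carboxylic acid or a longer chain at this position would give a step beyond the scatter remains open. Also open, as far as these compounds go, is whether these four compounds would separate at any other concentration.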